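Swapping a pyrazolyl chain end for phenyl: clearance expected to rise

The source may report more compounds than this note shows. Statements on the series, on what has been measured and on what is new or still open speak of the compounds shown alone.

The shared core of the three measured compounds carries a chain off the amide, and its end differs. Compound 1 `COc1ccc(F)cc1N1C(=O)CSC1c1cccc(C(=O)NCCCCn2cccn2)c1` gives in an ADME assay on microsomes from liver (Canis lupus familiaris) for metabolic stability, read by LC-MS, using NADPH, with a stated time of 10 min, tested at 0.1 uM (on this read-out higher numbers stand for fast clearance and lower numbers for slow clearance), a value of 480 mL.min-1.g-1, the lowest of the three numbers. Compound 2 `C#Cc1cc(C(=O)NCCCCc2ccccc2)cc(C2SCC(=O)N2c2ccccc2OC)c1` gives 1750 mL.min-1.g-1 and compound 3 `COc1ccccc1N1C(=O)CSC1c1cc(F)cc(C(=O)NCCCCc2ccccc2)c1` gives 2170 mL.min-1.g-1; both of these carry a phenyl at the chain end. Within the data shown here, the only single-point step among them, a 1.2-fold higher number from compound 2 to compound 3 (0.09 log units; within the scatter), concerns the aromatic carbon and not the chain end, so it does not bear on the change at hand. Compound 4 `COc1ccc(F)cc1N1C(=O)CSC1c1cccc(C(=O)NCCCCc2ccccc2)c1` differs from compound 1 by phenyl in place of 1H-pyrazol-1-yl on a saturated chain carbon, four bonds along the chain from an amide-type nitrogen. Among the measured compounds shown here, no step for this exact change has been measured; what the values of compound 2 and compound 3 show is that the phenyl-ended analogs stand well above compound 1. Compound 4 is therefore expected to move upward, a 3.1-fold higher number from compound 1 to compound 4 (0.49 log units; beyond the scatter), toward those two. The value of compound 4 in this assay is estimated at 1500 mL.min-1.g-1, within 700 mL.min-1.g-1 to 3200 mL.min-1.g-1.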

Compound 4, intrinsic clearance in microsomes: 1650 mL.min-1.g-1
Compound 4: middle estimate off by 1.1-fold (0.04 log units), on the low side, within the range that was stated.
By their numbers in this assay, from the lowest: compound 1; then compounds 4, 2 and 3 (each within the scatter of the next).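

In this assay, phenyl in place of 1H-pyrazol-1-yl on a saturated chain carbon, four bonds along the chain from an amide-type nitrogen, gives a 3.4-fold higher number from compound 1 to compound 4 (0.54 log units; beyond the scatter). Among these compounds, this is the first step that isolates the chain end, since the rest of the molecule stays the same, and it shows that this single change is enough to raise clearance beyond the scatter. Nothing available here accounts for the rise.

Still open, from the compounds shown here alone, is how other chain ends would read on this core, such as a pyridine ring, an amine or a carboxylic acid in place of the phenyl. Also open, going by these compounds, is whether the step would keep its size on a shorter or longer chain, or on the cores of compound 2 and compound 3.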